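The source may hold more compounds than are shown below. What is called first, only, known or untested is meant among the compounds shown, and "the series" means these compounds.

Compound 1 (`O=C(CCCCCCc1nc(-c2ccc(C(F)(F)F)cc2)no1)NO`), compound 2 (`O=C(CCCCCCc1nc(-c2ccc(F)cc2)no1)NO`) and compound 3 (`O=C(CCCCCCc1nc(-c2ccccc2Cl)no1)NO`) share one core and a saturated chain that ends in a carbonyl carrying hydroxyamino. They differ only in the aromatic group. In a functional assay on U-937 cells (Homo sapiens) for antiproliferative activity, read by MTT assay, with a stated time of 72 h (a lower number here means a stronger inhibitor, a higher number a weaker inhibitor), compound 1 gives 2870 nM, compound 2 gives 1930 nM and compound 3 gives 750 nM. Compound 2 cannot be told apart from compound 1, as the data show a 1.5-fold lower number from compound 1 to compound 2 (0.17 log units; within the scatter). Compound 3 does separate, with a 2.6-fold lower number from compound 2 to compound 3 (0.41 log units; beyond the scatter).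

Compound 4 (`O=C(CCCCCCc1nc(-c2ccc(F)cc2)no1)C(F)(F)F`) changes a different place: trifluoromethyl in place of hydroxyamino on a carbonyl carbon, (trifluoromethyl in place of hydroxyamino on a carbonyl carbon). For the measured compounds named here, both measured steps concern the aromatic group, so neither bears directly on this change, and no measured compound lacks hydroxyamino. They show only that edits at that other place moved the number little. The change in compound 4 removes a group that all three measured compounds keep, so a larger step is expected in this assay, towards a higher number and a weaker inhibitor. This is a judgement, not a measured trend. For compound 4 the expected value is 12000 nM, with an estimated range from 4000 nM to 40000 nM. The expected change is a 6.2-fold higher number from compound 2 to compound 4 (0.79 log units; beyond the scatter).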

Compound 4, half-maximal inhibitory concentration: 2350 nM
For compound 4 the middle estimate is 5.1-fold (0.71 log units) above the measured one; measured number below the stated range.
By their numbers in this assay, from the lowest: compound 3; then compounds 2, 4 and 1 (each within the scatter of the next).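

Compound 4 is the first compound shown with a change at the carbonyl end of the chain rather than at the aromatic group, and in this assay putting trifluoromethyl in place of hydroxyamino gives a 1.2-fold higher number from compound 2 to compound 4 (0.09 log units; within the scatter) and so leaves the two compounds indistinguishable. Hydroxyamino, which all three earlier compounds keep, is therefore not needed for a number of this size in this one pair, although a single pair cannot show whether the same holds with other aromatic groups. Nothing at hand gives a reason for this result.

For the compounds shown here, a cell-based read-out such as this one cannot show whether compound 2 and compound 4 act on cells in the same way, only that their numbers cannot be told apart. As far as these compounds go, it also remains open whether the same swap would leave the number unchanged with the 2-chlorophenyl group of compound 3, and how the number would respond to other groups on the carbonyl carbon, such as a methyl, an amine or the hydroxyl of a carboxylic acid, or to a longer chain.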